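From compound 3 to compound 4: one side chain exchanged

A few compounds are considered here, and "the series" means these few. Any claim that something is new, unique, unknown or untested is made for them only; others in the source may bear on it.

Compound 1 `CCCCNc1nc(N)nc2ccn(Cc3ccccn3)c12`: > 24000 nM
Compound 2 `Nc1nc(NCc2ncco2)c2c(ccn2Cc2ccccn2)n1`: > 24000 nM
Compound 3 `Cc1cc(CNc2nc(N)nc3ccn(Cc4ccccn4)c23)no1`: > 24000 nM

In an ADME assay on HEK293 cells (Homo sapiens) for cytotoxicity, read by ATP content, with a stated time of 6 h (on this read-out lower numbers stand for higher toxicity in this test and higher numbers for lower toxicity in this test), compound 3 gives > 24000 nM, which is a limit and not a number. The other two compounds stand at the same limit, as the limit of > 24000 nM in this assay, at which 3 of the 3 values shown sit, shows. Compound 4 `Cc1cnc(COc2nc(N)nc3ccn(Cc4ccccn4)c23)o1` differs from compound 3 at one place on the shared core: (5-methyl-1,3-oxazol-2-yl)methoxy in place of ((5-methyl-1,2-oxazol-3-yl)methyl)amino on an aromatic carbon. The steps nearest to this change are a step that the two limits leave unreadable from compound 2 to compound 3, a step that the two limits leave unreadable from compound 1 to compound 3 and a step that the two limits leave unreadable from compound 1 to compound 2, and none has a readable size. Among the compounds with values here, no measured step replaces the amino link with an oxygen link. On this thin basis, no change beyond the scatter is expected in this assay. The estimated step is a step that the limit leaves unreadable from compound 3 to compound 4. The estimate for compound 4 is 26000 nM, within an expected range of 12000 nM to 50000 nM.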

Compound 4, half-maximal cytotoxic concentration: > 24000 nM
Compound 4 was reported as a limit; the forecaster's own chance of this, stated with the estimate: 85%; the middle value is on the limit's open side.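

Compound 4 is reported only as a limit, as are compound 1, compound 2 and compound 3, so no step among them can be read: the limit of > 24000 nM in this assay, at which 4 of the 4 values shown sit.

The compounds shown leave open how far past that limit each one lies in this assay.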